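From compound 3 to compound 4: methyl to ethyl

The source may report more compounds than this note shows. Statements on the series, on what has been measured and on what is new or still open speak of the compounds shown alone.

In an ADME assay on microsomes from liver (Homo sapiens) for metabolic stability, with a stated time of 10 min (on this read-out lower numbers stand for a less stable compound and higher numbers for a more stable compound), compound 1 `CC[C@]1(C(=O)O)CC[C@H](C(=O)N2CC[C@](c3ccc(C(F)(C(F)(F)F)C(F)(F)F)cc3)(S(=O)(=O)c3ccc(F)cc3)C2)CC1` gives 100%, and compound 2 `COC[C@]1(C(=O)N2CC[C@](c3ccc(C(F)(C(F)(F)F)C(F)(F)F)cc3)(S(=O)(=O)c3ccc(F)cc3)C2)CC[C@H](C(=O)O)CC1` gives 100%. For compound 3 `CC1(C(=O)N2CC[C@](c3ccc(C(F)(C(F)(F)F)C(F)(F)F)cc3)(S(=O)(=O)c3ccc(F)cc3)C2)CCS(=O)(=O)CC1` the entry reads "not determined" (no result reported), so it offers no number to start from. Compound 4 `CCC1(C(=O)N2CC[C@](c3ccc(C(F)(C(F)(F)F)C(F)(F)F)cc3)(S(=O)(=O)c3ccc(F)cc3)C2)CCS(=O)(=O)CC1` differs from compound 3 by methyl in place of hydrogen on a saturated chain carbon bound to a saturated ring carbon. This turns 4-methyl-1,1-dioxothian-4-yl into 4-ethyl-1,1-dioxothian-4-yl. Going by the values given here, only one measured step offers guidance, and it concerns a different group: no change at the digits printed from compound 1 to compound 2 (within the scatter). On that loose evidence, no step beyond the scatter is expected from the added methyl, in either direction. The estimate therefore leans on the values of compound 1 and compound 2, with a wide range. Compound 4 is expected at 92%, with an estimated range of 72% to 100%.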

Compound 4, percent of the compound remaining: 3%
Compound 4: middle estimate off by 89 percentage points, on the high side, outside the stated range (below it).
By their numbers in this assay, from the lowest: compound 4; then compounds 1 and 2 (each within the scatter of the next).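

The position on the carbonyl carbon, flat between compound 1 and compound 2, proves highly sensitive in this assay: there is a number 97 percentage points lower from compound 2 to compound 4 (beyond the scatter) with 4-ethyl-1,1-dioxothian-4-yl in place of 4-carboxy-1-(methoxymethyl)cyclohexyl, and a number 97 percentage points lower from compound 1 to compound 4 (beyond the scatter) with it in place of 4-carboxy-4-ethylcyclohexyl. On these data alone, the step from compound 3 cannot be read, so the part played by the added methyl stays unknown. No available evidence accounts for the drop. Still open, as far as these compounds go, is whether an amine or a hydroxyl in place of the ethyl would change the read-out.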